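A few compounds are considered here, and "the series" means these few. Any claim that something is new, unique, unknown or untested is made for them only; others in the source may bear on it.

Compound 1 `O=C(/C=C/c1ccc(O)cc1)c1ccc2occc2c1O` gives 10900 nM in an assay on isolated protein for inhibition of lysosomal alpha-glucosidase (Rattus norvegicus), read by spectrophotometry, with a stated time of 5 min; on this read-out higher numbers stand for weaker inhibition and lower numbers for stronger inhibition.
Compound 2 `O=C(/C=C/c1ccc(O)c(O)c1)c1cc2ccoc2cc1O` gives 18900 nM in this assay.

Compound 1 and compound 2 lie within the usual scatter of each other in this assay, so neither can be said to inhibit more strongly. Compound 3 `COc1ccc(/C=C/C(=O)c2ccc3occc3c2O)cc1` is not yet measured; it differs from compound 1 by methyl in place of hydrogen on an oxygen on an aromatic ring. Among the measured compounds shown here, no measured pair shows this change, so the expectation rests on the change alone. A modest step toward weaker inhibition is expected, a 1.8-fold higher number from compound 1 to compound 3 (0.26 log units; within the scatter), though it may still fall within the scatter. Compound 3 is therefore estimated at 20000 nM, with a range from 8000 nM to 60000 nM.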

Compound 3, half-maximal inhibitory concentration: 9200 nM
For compound 3 the middle estimate is 2.2-fold (0.34 log units) above the measured one; the range from low to high includes it.
By their numbers in this assay, from the lowest: compounds 3, 1 and 2 (each within the scatter of the next, the first and the last beyond it).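

Going from hydroxy to methoxy on this aromatic ring gives a 1.2-fold lower number from compound 1 to compound 3 (0.07 log units; within the scatter) in this assay and is the first reading of this change. At this position, the hydrogen on the oxygen can therefore be replaced by methyl with no difference that stands out from the scatter. No available measurement addresses why the number stays within the scatter.

Going by these compounds, whether a longer chain on this oxygen, or an amine in place of the hydroxy, would also stay within the scatter remains open. So does whether methyl on the hydroxy groups of compound 2 would behave the same way.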